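The source may hold more compounds than are shown below. What is called first, only, known or untested is meant among the compounds shown, and "the series" means these compounds.

Of the compounds shown here, three built on one shared core have been measured in a functional assay (trachea) with Rattus norvegicus as the target; a higher number here means a more potent compound, by a factor of ten per unit of this negative logarithm, a lower number a less potent compound. Compound 1 `CC1(C)C=C(n2ccccc2=O)c2cc(OCC(=O)c3ccccc3)ccc2O1` gives 4.69. Compound 2 `CC1(C)C=C(n2ccccc2=O)c2cc(OCC(=O)c3ccc(F)cc3)ccc2O1` gives 4.77, and compound 3 `CC1(C)C=C(n2ccccc2=O)c2cc(OC(=O)Nc3ccccc3)ccc2O1` gives 4.89. Compound 2 differs from compound 1 by fluoro in place of hydrogen on an aromatic carbon, a change that made a number 0.08 log units higher from compound 1 to compound 2 (within the scatter). Compound 3 differs from compound 1 by phenylcarbamoyl in place of benzoylmethyl on an oxygen on an aromatic ring, which made a number 0.20 log units higher from compound 1 to compound 3 (within the scatter). The two values of compound 2 and compound 3 lie within the scatter of each other, as a number 0.12 log units higher from compound 2 to compound 3 (within the scatter) shows.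

Compound 4 `CC1(C)C=C(n2ccccc2=O)c2cc(OC(=O)Nc3ccccc3F)ccc2O1` has not yet been measured. It differs from compound 3 by fluoro in place of hydrogen on an aromatic carbon. For the measured compounds named here, this is the same kind of change as the one from compound 1 to compound 2, though not the same: there the fluoro sits para to a large group, here it sits ortho to a large group, and the cores carrying it differ as described. The step expected from compound 3 to compound 4 is a number 0.06 log units higher from compound 3 to compound 4 (within the scatter), resting on the earlier step of a number 0.08 log units higher from compound 1 to compound 2 (within the scatter) for the same kind of change. Compound 4 is therefore estimated at 4.95, expected to fall between 4.6 and 5.3.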

Compound 4, logarithm of the reciprocal of the active concentration, log(1/C): 4.22
For compound 4 the middle estimate is 0.73 log units above the measured one; the whole stated range lies above it.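

In this assay, fluoro in place of hydrogen on an aromatic carbon did not carry over from one core to the other: the same change on two cores in this assay, a number 0.08 log units higher (within the scatter) from compound 1 to compound 2 and a number 0.67 log units lower (beyond the scatter) from compound 3 to compound 4, 0.75 log units apart, beyond the scatter of two such steps

The fall, a number 0.67 log units lower from compound 3 to compound 4 (beyond the scatter), also holds against the two compounds with the other chain on the oxygen, with a number 0.55 log units lower from compound 2 to compound 4 (beyond the scatter) and a number 0.47 log units lower from compound 1 to compound 4 (beyond the scatter). This does not show why the step changed, since the fluoro in compound 4 sits ortho to a large group within a (2-fluorophenyl)carbamoyl group, while compound 2 carries a 4-fluorophenyl group on a different chain, so the place of the fluoro and the chain holding it differ together.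

The compounds shown leave open how a (4-fluorophenyl)carbamoyl group would compare with the (2-fluorophenyl)carbamoyl group of compound 4, a comparison that would change only the place of the fluoro. They also leave open whether a chloro or methyl group in that same place would bring a similar fall.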